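The compounds below may be only part of what the source reports. "The series", "measured", "known", "first", "only" and "open" are said of these compounds alone.

Measured so far:

Compound 1, `Nc1nc(NCCNc2ncc(-c3ncc[nH]3)c(-c3ccccc3Cl)n2)ccc1[N+](=O)[O-]`: in an ADME assay on microsomes from liver (Rattus norvegicus) for metabolic stability (on this read-out higher numbers stand for a longer-lived compound and lower numbers for a shorter-lived compound), compound 1 gives > 0.5 h, which is a limit of the assay rather than a number.
Compound 2, `Nc1nc(NCCNc2ncc(-c3ncc[nH]3)c(-c3ccc(Br)cc3F)n2)ccc1[N+](=O)[O-]`: in this assay compound 2 gives > 0.5 h, again a limit.
Compound 3, `Nc1nc(NCCNc2ncc(-c3ncc[nH]3)c(-c3cc(F)c(Cl)cc3Cl)n2)ccc1[N+](=O)[O-]`: in this assay compound 3 gives > 0.5 h, also a limit.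

Compound 1 therefore stands at the ceiling of what was reported: all three values sit at the limit of > 0.5 h in this assay, at which 3 of the 3 values shown sit, so compound 1 cannot be ordered against compound 2 or compound 3. The compound not yet measured, compound 4, `Nc1nc(NCCNc2ncc(-c3ncc[nH]3)c(-c3ccc(Cl)cc3Br)n2)ccc1[N+](=O)[O-]`, differs from compound 1 in one place: 2-bromo-4-chlorophenyl in place of 2-chlorophenyl on an aromatic carbon. The measured steps that bear on this change all swap the same aryl group, namely a step that the two limits leave unreadable from compound 1 to compound 2, a step that the two limits leave unreadable from compound 1 to compound 3 and a step that the two limits leave unreadable from compound 2 to compound 3. Their sizes cannot be read because every value involved sits at the limit of > 0.5 h in this assay, at which 3 of the 3 values shown sit. What the three compounds show is that swapping one halogenated phenyl group for another has not yet pulled any compound below that limit, so no step beyond the scatter is expected in this assay. Compound 4 is expected to behave like compound 1, with an estimated step that the limit leaves unreadable from compound 1 to compound 4. For compound 4 the estimate is 0.8 h, with a range from 0.4 h to 2 h, most likely reported only as a limit again.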

Compound 4, half-life: > 0.5 h
Compound 4: a limit, no number; the forecaster's own chance of this, stated with the estimate: 85%; the middle value lies beyond the limit too.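

In this assay compound 4 again gives only a limit, and its steps to compound 1, compound 2 and compound 3 cannot be read, because all four compounds stop at the same point: the limit of > 0.5 h in this assay, at which 4 of the 4 values shown sit. On these data alone, how long each of these four compounds actually lasts, and whether their different phenyl groups change that at all, remains open.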